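The compounds below may be only part of what the source reports. "The series", "measured", "known", "first", "only" and "open" are said of these compounds alone.

Compounds measured so far:
Compound 1, `C=CCn1c(=O)/c(=C\c2cccc(C)c2)[nH]c(=O)/c1=C\c1ccccc1OC`, 16000 nM
Compound 2, `C=CCn1c(=O)/c(=C\c2cccc(F)c2)[nH]c(=O)/c1=C\c1ccccc1OC`, 6500 nM
Compound 3, `C=CCn1c(=O)/c(=C\c2ccccc2F)[nH]c(=O)/c1=C\c1ccccc1OC`, 20000 nM

All three share one core and were tested in a functional assay on MOLT-4 cells (Homo sapiens) for cytotoxicity, read by CCK-8 assay, with a stated time of 72 h; on this read-out higher numbers stand for weaker inhibition and lower numbers for stronger inhibition. Compound 3 has the highest number of the three: its nearest neighbour is compound 1, separated by a 1.3-fold higher number from compound 1 to compound 3 (0.10 log units; within the scatter), a gap that stays within the scatter, while compound 2 lies further away by a 3.1-fold higher number from compound 2 to compound 3 (0.49 log units; beyond the scatter), a gap beyond it.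

Compound 4, `C=CCn1c(=O)/c(=C\c2cccc(Cl)c2)[nH]c(=O)/c1=C\c1ccccc1OC`, is not yet measured. It differs from compound 3 at one point: 3-chlorophenyl in place of 2-fluorophenyl on a double-bonded chain carbon bound to an aromatic carbon.

Within the data shown here, two measured steps bear on this change. The step of a 3.1-fold higher number from compound 2 to compound 3 (0.49 log units; beyond the scatter) shows that moving from 3-fluorophenyl to 2-fluorophenyl raised the number modestly, so returning to a 3-substituted phenyl might be expected to undo part of that rise. Among the measured compounds shown here, the step of a 2.5-fold lower number from compound 1 to compound 2 (0.39 log units; beyond the scatter) shows that fluoro in place of methyl on that 3-substituted phenyl lowered the number modestly, placing 3-methylphenyl and 3-fluorophenyl apart; chlorine has no measured precedent here, so a value between those of compound 1 and compound 2 seems most plausible. Compound 4 is therefore expected to give a modestly lower number than compound 3, a step of about a 2.2-fold lower number from compound 3 to compound 4 (0.35 log units; beyond the scatter). Compound 4 is estimated at 9000 nM, with a range from 3500 nM to 22000 nM.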

Compound 4, half-maximal inhibitory concentration: 4900 nM
For compound 4 the middle estimate is 1.8-fold (0.26 log units) above the measured one; measured number inside the range.
By their numbers in this assay, from the lowest: compounds 4 and 2 (each within the scatter of the next); then compounds 1 and 3 (each within the scatter of the next).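

In this assay, 3-chlorophenyl in place of 2-fluorophenyl gives a 4.1-fold lower number from compound 3 to compound 4 (0.61 log units; beyond the scatter), so a chloro group on the 3-substituted phenyl gives a number clearly lower than that of the 2-fluorophenyl compound. Among these compounds, the step with chloro in place of fluoro, a 1.3-fold lower number from compound 2 to compound 4 (0.12 log units; within the scatter), stays within the scatter, so these two groups cannot be told apart at this place, which the single 3-fluorophenyl compound could not show. Chloro in place of methyl gives a 3.3-fold lower number from compound 1 to compound 4 (0.51 log units; beyond the scatter), which shows that the earlier gap between the 3-fluorophenyl and 3-methylphenyl compounds is matched by 3-chlorophenyl and sets the 3-methylphenyl compound apart from both 3-halophenyl compounds.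

Nothing given here accounts for why these groups separate in this way. The compounds shown leave open whether a 2-chlorophenyl group would give a number like that of compound 3 or like that of compound 4, and whether a 3-bromophenyl, 3-methoxyphenyl or 3-aminophenyl group would stay with compound 2 and compound 4 or fall with compound 1.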